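This account rests on a few compounds, and the source may have more. Where it says the series, first, only, none or still open, it means among the compounds named here.

Measured compounds and their responses in an assay on HEK293 cells for positive allosteric modulation of metabotropic glutamate receptor 3 (Rattus norvegicus), read by thallium flux, with a stated time of 2.5 min; on this read-out lower numbers stand for smaller maximal responses and higher numbers for larger maximal responses:
compound 1 `COc1cc(C(=O)O)ccc1OCCCCOc1ccc(C(=O)CC(C)C)c(O)c1C` gives 73.9%
compound 2 `Cc1c(OCCCCOc2ccc(C(=O)O)cc2)ccc(C(=O)CC(C)C)c1O` gives 51.9%
compound 3 `Cc1c(OCCCCOc2ccc(C(=O)O)cc2)ccc(C(=O)CC(C)C)c1C` gives 16.6%

Compound 2 stands second highest of these three in this assay. Two single-point steps are known: a number 22 percentage points lower from compound 1 to compound 2 (beyond the scatter), and a number 35.3 percentage points lower from compound 2 to compound 3 (beyond the scatter). Compound 4 `Cc1c(OCCCCOc2ccc(F)c(C(=O)O)c2)ccc(C(=O)CC(C)C)c1O` differs from compound 2 in one place: 3-carboxy-4-fluorophenyl in place of 4-carboxyphenyl on an oxygen on a saturated carbon. Among the compounds with values here, both known steps alter the other end of the shared core, so neither bears directly on this change; they show only that single changes elsewhere moved the response by modest to large amounts. With no direct guide, a step in either direction cannot be ruled out, and none beyond the scatter is firmly expected. Compound 4 is therefore estimated at 47%, within 25% to 70%. This estimate means that a number 4.9 percentage points lower from compound 2 to compound 4 (within the scatter) is expected.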

Compound 4, largest response reached (reported as percent of maximum), in percent of the reference or control that the assay uses: 81.7%
Compound 4: middle estimate off by 34.7 percentage points, on the low side, and the stated range ends below it.
By their numbers in this assay, from the lowest: compound 3; then compound 2; then compounds 1 and 4 (each within the scatter of the next).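

The earlier steps shown here changed only the other end of the shared core, whereas this one shows that the group on an oxygen on a saturated carbon also shapes the maximal response, with a number 29.8 percentage points higher from compound 2 to compound 4 (beyond the scatter). The swap changes two things at once, the place of the carboxy group on the ring and the added fluorine, so neither can be credited alone. Nothing measured here gives a reason for the rise. Still open, from the compounds shown here alone, is how 3-carboxyphenyl without fluorine would compare with compound 4, and whether a tetrazole could replace the carboxylic acid.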